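A Chloro Swap at the Assay Limit

This account rests on a few compounds, and the source may have more. Where it says the series, first, only, none or still open, it means among the compounds named here.

In a functional assay on PC-3 cells (Homo sapiens) for cytotoxicity, read by sulforhodamine B assay, with a stated time of 72 h (a higher number here means a weaker inhibitor, a lower number a stronger inhibitor), compound 1 (`COc1cc(/C=C/C(=O)/C=C(O)/C=C/c2ccc(OC(C)(C)C(=O)Nc3ccc(Cl)c(C(F)(F)F)c3)c(OC)c2)ccc1O`) gives > 100000 nM, which is a limit and not a number. Compound 2 (`COc1ccc(/C=C/C(=O)/C=C(O)/C=C/c2ccc(OC(C)(C)C(=O)Nc3ccc(C#N)c(C(F)(F)F)c3)c(OC)c2)cc1OC`) gives > 100000 nM, likewise a limit. Compound 2 therefore has no exact position, and the only reference is the limit of > 100000 nM in this assay, at which 2 of the 2 values shown sit. Compound 3 (`COc1ccc(/C=C/C(=O)/C=C(O)/C=C/c2ccc(OC(C)(C)C(=O)Nc3ccc(Cl)c(C(F)(F)F)c3)c(OC)c2)cc1OC`) carries chloro in place of cyano on an aromatic carbon, para to a large group: chloro in place of cyano on an aromatic carbon. No measured step sizes this change, so the expected a number no higher from compound 2 to compound 3 (the limit leaves the size open) stays within the usual scatter of this assay. Compound 3 is estimated at 100000 nM, with an expected range from 40000 nM to 200000 nM.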

Compound 3, half-maximal inhibitory concentration: > 100000 nM
Compound 3 ended at the assay's limit (the forecaster's own chance of this, stated with the estimate: 70%); the middle value sits exactly at the limit.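

No step from compound 2 to compound 3 or from compound 1 to compound 3 can be read, since all three values are limits: the limit of > 100000 nM in this assay, at which 3 of the 3 values shown sit.

The compounds shown leave open whether chloro in place of cyano, or methyl in place of hydrogen on the oxygen, makes any difference in this assay.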